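A few compounds are considered here, and "the series" means these few. Any claim that something is new, unique, unknown or untested is made for them only; others in the source may bear on it.

The series shares one core. Compound 1 `CCOC(=O)c1c(C)[nH]c(=O)c(C#N)c1-c1ccc(C)cc1` carries 4-methylphenyl on it, and compound 2 `CCOC(=O)c1c(C)[nH]c(=O)c(C#N)c1-c1ccc(C#N)cc1` differs only by cyano in place of methyl on an aromatic carbon. In a functional assay on HepG2 cells (Homo sapiens) for inhibition, read by MTT assay, with a stated time of 24 h (on this read-out lower numbers stand for stronger inhibition and higher numbers for weaker inhibition), compound 1 gives 11900 nM, and in this assay compound 2 gives 20200 nM; the two numbers lie within the scatter of each other, so compound 1 stands at neither end of any real spread. Going by the values given here, the only measured step, a 1.7-fold higher number from compound 1 to compound 2 (0.23 log units; within the scatter), changes one group on the phenyl ring and stays within the scatter.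

Compound 3 `CCOC(=O)c1c(C)[nH]c(=O)c(C#N)c1-c1cccs1` is not yet measured. Its change from compound 1 is thiophen-2-yl in place of 4-methylphenyl on an aromatic carbon. Here one six-membered aromatic ring of carbon only gives way to one five-membered aromatic ring with 1 hetero atom, a kind of change no measured step covers; the step from compound 1 to compound 2 only shows that altering a group on the aryl portion leaves the number within the scatter. Nothing measured supports a shift in either direction. The expectation for compound 3 is a number near that of compound 1, the step of a 1.0-fold higher number from compound 1 to compound 3 (0.00 log units; within the scatter) being expected to stay within the scatter. The estimate for compound 3 in this assay is 12000 nM, with a range from 5000 nM to 30000 nM.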

Compound 3, half-maximal inhibitory concentration: 74100 nM
Beside the measured number, compound 3's estimate is 6.2-fold (0.79 log units) below it; measured number outside the range, above it.
By their numbers in this assay, from the lowest: compounds 1 and 2 (each within the scatter of the next); then compound 3.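

The position on the shared core opposite the ring nitrogen, ortho to the cyano and ethoxycarbonyl groups, proves sensitive to the identity of the ring it carries: in this assay the exchange of 4-methylphenyl for thiophen-2-yl gives a 6.2-fold higher number from compound 1 to compound 3 (0.79 log units; beyond the scatter) and so leaves the scatter, which the substituent change on the phenyl ring, a 1.7-fold higher number from compound 1 to compound 2 (0.23 log units; within the scatter) did not do. Going by these compounds alone, at this position, then, replacing the whole aryl ring counts for more than the one substituent exchange seen so far, and the direction is towards weaker inhibition, although this rests on a single step and supports no general rule about five-membered rings. No measurement at hand bears on the reason for this step.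

The compounds shown leave open whether unsubstituted phenyl, thiophen-3-yl or furan-2-yl would fall with compound 1 or with compound 3, so the step cannot yet be assigned to the ring size, the sulfur atom or the loss of the methyl group. They also leave open how an amine or a carboxylic acid on the phenyl ring would read in this assay on this core.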